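Alpha-methyl branching on the acid chain of a biaryl series

The compounds below may be only part of what the source reports. "The series", "measured", "known", "first", "only" and "open" are said of these compounds alone.

Two measured compounds share a core in which a phenyl bearing a carboxylic acid side chain carries a second ring that in turn holds a benzyloxy-substituted ring. Compound 1 `O=C(O)CCc1ccccc1-c1cccc(-c2ccccc2OCc2ccccc2)c1` carries a 2-carboxyethyl chain, and in an assay on HEK293 cells for binding affinity to prostaglandin E2 receptor EP4 subtype (Homo sapiens) (a lower number here means a stronger inhibitor, a higher number a weaker inhibitor), compound 1 gives 1800 nM. Compound 2 `O=C(O)/C=C/c1ccccc1-c1cccc(-c2ccccc2OCc2ccccc2)c1` carries the unsaturated 2-carboxyethenyl chain instead, and in this assay compound 2 gives 1700 nM. The step of a 1.1-fold lower number from compound 1 to compound 2 (0.02 log units; within the scatter) shows that swapping the saturated chain for the unsaturated one changed nothing beyond the scatter. Compound 2 thus holds the lowest of the two numbers, with compound 1 within the scatter of it.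

Compound 3 `CC(Cc1ccccc1-c1cccc(-c2ccccc2OCc2ccccc2)c1)C(=O)O` departs from compound 2 by 2-carboxypropyl in place of 2-carboxyethenyl on an aromatic carbon. Among the compounds with values here, the only step on record, a 1.1-fold lower number from compound 1 to compound 2 (0.02 log units; within the scatter), concerns the same side chain and was flat, so for compound 3 the expectation in this assay is a step of a 1.1-fold higher number from compound 2 to compound 3 (0.02 log units; within the scatter), within the scatter. Compound 3 is therefore estimated at 1800 nM, with a range from 700 nM to 4500 nM.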

Compound 3, inhibition constant: 1200 nM
For compound 3 the middle estimate is 1.5-fold (0.18 log units) above the measured one; low and high end bracket the measured number.
By their numbers in this assay, from the lowest: compounds 3, 2 and 1 (each within the scatter of the next).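

Measured in this assay the new compound gives a 1.4-fold lower number from compound 2 to compound 3 (0.15 log units; within the scatter) when 2-carboxypropyl takes the place of 2-carboxyethenyl on an aromatic carbon, and a 1.5-fold lower number from compound 1 to compound 3 (0.18 log units; within the scatter) when methyl takes the place of hydrogen on the saturated chain carbon bound to the carbonyl carbon. This position, ortho to a large group, has now carried three different acid chains, and neither the methyl branch on the saturated chain nor the exchange of the unsaturated chain for the branched one moves the number beyond the scatter, so the three compounds stand together with no order among them. No evidence is available that would account for this flat result.

The compounds shown leave open whether a larger branch on the same chain carbon, such as an ethyl group or a second methyl, or a longer chain carrying the carboxylic acid, would shift the number beyond the scatter. They also leave open what a tetrazole or a primary amide in place of the carboxylic acid would do at this position.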